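The source may report more compounds than this note shows. Statements on the series, on what has been measured and on what is new or still open speak of the compounds shown alone.

Measured compounds in a functional assay on OVCAR-3 cells (Homo sapiens) for cytotoxicity, read by sulforhodamine B assay; a lower number here means a stronger inhibitor of growth, a higher number a weaker inhibitor of growth:
Compound 1, `CC1=CC[C@@H]([C@@](C)(O)CCCC(C)(C)NC=S)CC1`: compound 1 gives 12100 nM
Compound 2, `CC1=CC[C@@H]([C@@](C)(O)CCCC(C)(C)NC(=S)N/N=C\c2ccc(C)cc2)CC1`: compound 2 gives 6020 nM
Compound 3, `CC1=CC[C@@H]([C@@](C)(O)CCCC(C)(C)NC(=S)N/N=C\c2ccc(O)cc2)CC1`: compound 3 gives 6230 nM

Compound 2 carries the lowest of the three numbers, yet this says little: its gaps to compound 3 and to compound 1 both fall within the usual scatter of this assay, so the three compounds cannot be told apart on these numbers.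

Compound 4, `CC1=CC[C@@H]([C@@](C)(O)CCCC(C)(C)NC(=S)N/N=C\c2ccc(N(C)C)cc2)CC1`, is made from compound 2 by one change: dimethylamino in place of methyl on an aromatic carbon. Within the data shown here, only one measured step touches the same place on the ring. There, a 1.0-fold higher number from compound 2 to compound 3 (0.01 log units; within the scatter), so exchanging the group at that position left the number essentially unmoved. Among the measured compounds shown here, no measured step shows what a dimethylamino group does, so the expectation rests on that single comparison alone.

On this basis the step of a 1.1-fold lower number from compound 2 to compound 4 (0.04 log units; within the scatter) is expected to stay within the scatter. Compound 4 is therefore estimated at 5500 nM, with a plausible range from 2200 nM to 14000 nM.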

Compound 4, concentration for 50% growth inhibition: 3600 nM
Compound 4: middle estimate off by 1.5-fold (0.18 log units), on the high side; low and high end bracket the measured number.
By their numbers in this assay, from the lowest: compounds 4, 2, 3 and 1 (each within the scatter of the next, the first and the last beyond it).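

With dimethylamino, the position on the aromatic ring has now been tested with a third group, and this assay still does not separate it from the other two: dimethylamino in place of methyl gives a 1.7-fold lower number from compound 2 to compound 4 (0.22 log units; within the scatter), and dimethylamino in place of hydroxy gives a 1.7-fold lower number from compound 3 to compound 4 (0.24 log units; within the scatter). This position, para to a large group, therefore accepts a group of three heavy atoms, with one hydrogen-bond acceptor, without a change beyond the scatter, which the swap of methyl for hydroxy alone could not show. Nothing available explains why the number stays so close across these groups.

Still open, as far as these compounds go, is whether a carboxylic acid or a longer chain at this position would move the number beyond the scatter. From the compounds shown here alone, whether a second group elsewhere on the same ring would do so is also open.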